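Methyl Removal on a Saturated Ring Carbon: Cytotoxicity Outlook

The source may hold more compounds than are shown below. What is called first, only, known or untested is meant among the compounds shown, and "the series" means these compounds.

Of the compounds shown here, three have been tested in an ADME assay on MRC5 cells (Homo sapiens) for cytotoxicity, read by resazurin assay, with a stated time of 72 h; on this read-out lower numbers stand for stronger inhibition and higher numbers for weaker inhibition. For the measured compounds named here, compound 1 `CC1(COCc2ccc(-c3ccc(F)cc3)cc2)CCn2cc([N+](=O)[O-])nc2O1` is the first of them. In this assay compound 1 reaches only the assay limit, reported as > 64000 nM. Compound 2 `O=[N+]([O-])c1cn2c(n1)OC(COc1ccc(-c3ccc(OC(F)(F)F)cc3)cn1)CC2` is the second. In this assay compound 2 also stops at a limit, given as > 64000 nM. Compound 3 `CC1(COc2ccc(-c3ccc(OC(F)(F)F)cc3)cn2)CCn2cc([N+](=O)[O-])nc2O1` is the third. In this assay compound 3 likewise returns a limit, > 64000 nM.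

Compound 3 and compound 2 differ in one place: hydrogen in place of methyl on a saturated ring carbon. The step this change made, a step that the two limits leave unreadable from compound 3 to compound 2, has no readable size, since both ends of it sit at the limit of > 64000 nM in this assay, at which 3 of the 3 values shown sit.

Compound 4 `O=[N+]([O-])c1cn2c(n1)OC(COCc1ccc(-c3ccc(F)cc3)cc1)CC2` has not yet been measured in this assay. Going by the values given here, it differs from compound 1 by hydrogen in place of methyl on a saturated ring carbon, which is the same change as the one that turns compound 3 into compound 2, made at the same place. Compound 1 and compound 3 share the rest of their structure only in part; the difference between the two cores is not broken down here.

For compound 4 the expectation rests on compound 1, whose value is the limit > 64000 nM, and on the unreadable step that the two limits leave unreadable from compound 3 to compound 2 that the same change gave elsewhere. The step from compound 1 to compound 4 is expected to be a step that the limit leaves unreadable from compound 1 to compound 4. Compound 4 is therefore estimated at 100000 nM in this assay, expected to fall between 40000 nM and 300000 nM, most likely again as a limit rather than a number.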

Compound 4, half-maximal inhibitory concentration: > 64000 nM
Compound 4: a limit, no number; the forecaster's own chance of this, stated with the estimate: 90%; the middle value lies beyond the limit too.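

In this assay compound 4, like compound 1, stops at a limit and gives no number, so no size can be read for the step between compound 1 and compound 4: (the limit of > 64000 nM in this assay, at which 4 of the 4 values shown sit). The compounds shown leave open what hydrogen in place of methyl on a saturated ring carbon does to cytotoxicity, and at what concentration, if any, any of them would give a measurable value.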